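Replacing a Methyl on Ring Nitrogen by 3-Methylphenyl

The source may hold more compounds than are shown below. What is called first, only, known or untested is meant among the compounds shown, and "the series" means these compounds.

Compound 1 `COc1cc(-c2nccn2C)cc(OC)c1OC` carries a trimethoxyphenyl group on a five-membered ring with two nitrogens, and a methyl on one of those nitrogens. In a functional assay on MDA-MB-231 cells (Homo sapiens) for antiproliferative activity, read by MTT assay, with a stated time of 72 h (a lower number here means a stronger inhibitor, a higher number a weaker inhibitor), compound 1 gives only a limit of the assay, > 100000 nM, so it stands at the weak end of what this measurement can report. Compound 2 `COc1ccc(-n2ccnc2-c2cc(OC)c(OC)c(OC)c2)cc1[N+](=O)[O-]` is the second measured member of the set; in this assay compound 2 gives 7500 nM.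

Compound 3 `COc1cc(-c2nccn2-c2cccc(C)c2)cc(OC)c1OC` has not yet been measured. It differs from compound 1 in one place: 3-methylphenyl in place of methyl on an aromatic nitrogen. Within the data shown here, no measured pair in this set follows exactly this change, so the expected size of the step rests on the one clue at hand, namely that compound 1 sits at the limit of > 100000 nM in this assay, at which 1 of the 2 values shown sits, while the only compound in the set that carries an aromatic ring on that nitrogen, compound 2, reaches a measurable number.

On that basis compound 3 is expected to reach a measurable value, with the step of an at least 8.3-fold lower number from compound 1 to compound 3 (0.92 log units; beyond the scatter) pointing toward stronger inhibition. The estimate for compound 3 in this assay is 12000 nM, within a range from 2000 nM to 80000 nM.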

Compound 3, half-maximal inhibitory concentration: 11700 nM
Compound 3: middle estimate off by 1.0-fold (0.01 log units), on the high side; low and high end bracket the measured number.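

Replacing methyl with 3-methylphenyl on an aromatic nitrogen gives, in this assay, an at least 8.5-fold lower number from compound 1 to compound 3 (0.93 log units; beyond the scatter). This single change shows that a six-membered aromatic ring of carbon only, carrying neither a nitro nor a methoxy group, is enough at this position to bring the shared core to a measurable value. Compound 1 stands at a limit of the assay and not at a number, so the step gives only a lower bound on the true change: the limit of > 100000 nM in this assay, at which 1 of the 3 values shown sits.

The compounds shown leave open whether the aromatic ring alone accounts for the step or whether its methyl also contributes, as plain phenyl and the other methylphenyl arrangements are not among them. They also leave open how this position would respond to a longer chain such as butyl, or to a phenyl ring bearing an amine or a carboxylic acid.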